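Dimethoxybenzyl for Cyanobenzyl in a Triazolyl Urea Series

The compounds below may be only part of what the source reports. "The series", "measured", "known", "first", "only" and "open" are said of these compounds alone.

Compound 1 `N#Cc1ccc(CN(C(=O)Nc2cc(C(F)(F)F)cc(C(F)(F)F)c2)n2cnnc2)cc1` is the reference point of this small set. In a functional assay on MCF7 cells (Homo sapiens) for cytotoxicity, read by MTT assay, with a stated time of 48 h (on this read-out lower numbers stand for stronger inhibition and higher numbers for weaker inhibition), compound 1 gives 7220 nM, the lowest of the two numbers recorded. Compound 2 `O=C(NC1CCCCC1)N(Cc1ccccn1)n1cnnc1` gives 46900 nM in this assay, a number that lies beyond the scatter from compound 1. Compound 3 `COc1ccc(CN(C(=O)Nc2ccc(C)cc2)n2cnnc2)cc1OC` gives > 50000 nM in this assay, which is a limit of the assay rather than a number.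

Compound 4 `COc1ccc(CN(C(=O)Nc2cc(C(F)(F)F)cc(C(F)(F)F)c2)n2cnnc2)cc1OC` has not yet been measured. It differs from compound 1 in one place (3,4-dimethoxyphenyl in place of 4-cyanophenyl on a saturated chain carbon bound to an amide-type nitrogen). Among the measured compounds shown here, no measured pair in this set isolates that change, so its size is unknown; the expectation is for a step toward weaker inhibition, and one large enough to fall beyond the scatter.

Because compound 3 with the same 3,4-dimethoxybenzyl group sits at the limit of > 50000 nM in this assay, at which 1 of the 3 values shown sits, compound 4 is expected to lose ground, estimated at 25000 nM with a range from 8000 nM to 60000 nM. The expected step from compound 1 to compound 4 is a 3.5-fold higher number from compound 1 to compound 4 (0.54 log units; beyond the scatter). There is a real chance that compound 4 also returns only a limit in this assay.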

Compound 4, half-maximal inhibitory concentration: 15500 nM
Estimate against measurement, compound 4: 1.6-fold (0.21 log units) above; the measured number falls inside the stated range.
By their numbers in this assay, from the lowest: compound 1; then compound 4; then compound 2. At a limit, above all of these: compound 3.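

Among the compounds shown here, this is the first pair in the set to isolate a change on a saturated chain carbon bound to an amide-type nitrogen: in this assay, 3,4-dimethoxyphenyl in place of 4-cyanophenyl gives a 2.1-fold higher number from compound 1 to compound 4 (0.33 log units; beyond the scatter). The step is modest, and the 4-cyanophenyl group is therefore not needed for a measured number, as compound 4 still gives 15500 nM without it. Compound 4 carries the same 3,4-dimethoxybenzyl group as compound 3, yet returns a number, so that group alone does not place a compound at the limit reached by compound 3: the limit of > 50000 nM in this assay, at which 1 of the 4 values shown sits.

The compounds shown leave open how much of the step comes from losing the nitrile and how much from adding the dimethoxy pattern, and whether the same change would give a step of similar size with a different group on the urea. A plain benzyl group, a 4-methoxybenzyl group or a 4-carboxybenzyl group at this place would begin to separate these contributions, with the rest of compound 1 held constant.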